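A few compounds are considered here, and "the series" means these few. Any claim that something is new, unique, unknown or untested is made for them only; others in the source may bear on it.

Measured in a functional assay on A549 cells (Homo sapiens) for cytotoxicity, read by MTT assay, with a stated time of 68 h; a higher number here means a weaker inhibitor, a lower number a stronger inhibitor:
Compound 1 `O=C(Nc1cccc(-c2cccc(F)c2)c1)C(Cl)Cl`: 9530 nM
Compound 2 `COc1cccc(-c2cc(NC(=O)C(Cl)Cl)cc(-c3cccc(OC)c3)c2)c1`: 9400 nM

Among the measured compounds shown here, only these two compounds have numbers so far, and they tell little. Compound 1 stands level with compound 2, as the two values lie within the scatter of each other. For the measured compounds named here, neither can be ranked above the other, and no step between compounds differing in one place has been measured.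

Compound 3 `O=C(Nc1cccc(-c2cccc(NC(=O)C(Cl)Cl)c2)c1)C(Cl)Cl` is the next to be read against compound 1. The change is ((dichloromethyl)carbonyl)amino in place of fluoro on an aromatic carbon, meta to a large group. The data offer no direct guide to this replacement. Compound 2, which carries different groups on its core, reads 9400 nM, and this gives no sign of a large swing. A modest move toward a lower number is expected, possibly no larger than the scatter, and the estimated change is a 1.4-fold lower number from compound 1 to compound 3 (0.13 log units; within the scatter). For compound 3 the expected value is 7000 nM, with an estimated range from 2500 nM to 20000 nM.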

Compound 3, half-maximal inhibitory concentration: 47900 nM
Estimate against measurement, compound 3: 6.8-fold (0.84 log units) below; the whole stated range lies below it.
By their numbers in this assay, from the lowest: compounds 2 and 1 (each within the scatter of the next); then compound 3.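

In this assay, among the compounds shown here, the change on this aromatic carbon, meta to a large group, is the first that can be read in one place: ((dichloromethyl)carbonyl)amino in place of fluoro gives a 5.0-fold higher number from compound 1 to compound 3 (0.70 log units; beyond the scatter). The two earlier compounds stood level and gave no sign of how far the number could move, whereas this replacement shows that the carbon is not indifferent to what it carries, since the step lies beyond the scatter and leaves compound 3 the weaker inhibitor of the pair. Nothing at hand bears on why the number rises with this replacement.

Only one replacement at this carbon is shown, so it stays open whether the rise belongs to the ((dichloromethyl)carbonyl)amino group itself or would follow any departure from fluoro. An amine, a hydroxyl or a carboxylic acid on the same aromatic carbon could separate those two readings. From the compounds shown here alone, compound 1 gives 9530 nM, and it also remains unknown whether any group there would bring the number down from this value.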